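The source may report more compounds than this note shows. Statements on the series, on what has been measured and on what is new or still open speak of the compounds shown alone.

In an assay on isolated protein for displacement of a labelled ligand from melanin-concentrating hormone receptor 1 (Homo sapiens) (a lower number here means a stronger inhibitor, a higher number a weaker inhibitor), compound 1 `CC(C)C(=O)NC1CCN(c2ccc3cc(NC(=O)CCc4ccc(C(F)(F)F)cc4)ccc3n2)C1` gives 1 nM. Among the measured compounds shown here, compound 2 `CC(=O)NC1CCN(c2ccc3cc(NC(=O)CCc4ccc(C(F)(F)F)cc4)ccc3n2)C1` gives 5 nM in this assay, the higher of the two numbers, and the only change between them, a 5.0-fold higher number from compound 1 to compound 2 (0.70 log units; beyond the scatter), is a modest step. Compound 3 `O=C(CCc1ccc(C(F)(F)F)cc1)Nc1ccc2nc(N3CC4CC3CO4)ccc2c1` differs from compound 2 by a group of 7 heavy atoms (5 carbon, 1 nitrogen, 1 oxygen; 2 five-membered non-aromatic rings with 1 hetero atom each) in place of a group of 9 heavy atoms (6 carbon, 2 nitrogen, 1 oxygen; one five-membered non-aromatic ring with 1 hetero atom), on an aromatic carbon. For the measured compounds named here, the single step measured so far concerns only the group on the carbonyl carbon and speaks faintly to a swap that replaces the whole 3-acetamidopyrrolidin-1-yl group. For compound 3 the expected step is a 3.0-fold higher number from compound 2 to compound 3 (0.48 log units; beyond the scatter), a somewhat higher number being the likelier outcome. Compound 3 is therefore estimated at 15 nM, within 3 nM to 80 nM.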

Compound 3, half-maximal inhibitory concentration: 13 nM
Compound 3: the middle estimate sits 1.2-fold (0.06 log units) above what was measured; the measured number falls inside the stated range.
By their numbers in this assay, from the lowest: compound 1; then compound 2; then compound 3.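

In this assay, the aromatic carbon next to the ring nitrogen accepts replacement of the entire 3-acetamidopyrrolidin-1-yl group, including its amide, at a modest cost: a 2.6-fold higher number from compound 2 to compound 3 (0.41 log units; beyond the scatter). The cost is large when the starting point is the isopropyl amide instead: a 13-fold higher number from compound 1 to compound 3 (1.11 log units; beyond the scatter). Nothing available here accounts for either step. On these data alone, how a simple amine or a morpholine ring would compare at this position remains open. So does whether a longer chain on the carbonyl carbon of compound 1 would lower the number further.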